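Three Anilinoquinazoline Thioacetamides, and a Fourth to Measure

The source may report more compounds than this note shows. Statements on the series, on what has been measured and on what is new or still open speak of the compounds shown alone.

Compound 1 `O=C(CSc1nc(Nc2ccccc2)c2ccccc2n1)Nc1cccc(Cl)c1` and compound 2 `O=C(CSc1nc(Nc2ccccc2)c2ccccc2n1)Nc1ccc(Cl)c(Cl)c1` share a core and differ only by a chloro in place of hydrogen on an aromatic carbon; in a functional assay on PC-3 cells (Homo sapiens) for inhibition, read by MTT assay, with a stated time of 72 h (on this read-out higher numbers stand for weaker inhibition and lower numbers for stronger inhibition), compound 1 gives 12600 nM and compound 2 gives 12100 nM, a change of a 1.0-fold lower number from compound 1 to compound 2 (0.02 log units; within the scatter). Compound 3 `C=CC(=O)Nc1cccc(NC(=O)CSc2nc(Nc3cccc(Cl)c3)c3ccccc3n2)c1` gives 12300 nM and lies within the scatter of both. Compound 4 `C=CC(=O)Nc1cccc(NC(=O)CSc2nc(Nc3ccc(Cl)cc3Cl)c3ccccc3n2)c1` differs from compound 3 by 2,4-dichlorophenyl in place of 3-chlorophenyl on a nitrogen on an aromatic ring. Within the data shown here, the only measured step of a comparable kind, an added chloro on an aromatic ring, stayed within the scatter, so no change beyond the scatter is expected for no change at the digits printed from compound 3 to compound 4 (within the scatter). Compound 4 is therefore estimated at 12300 nM, within a range of 6000 nM to 25000 nM.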

Compound 4, half-maximal inhibitory concentration: 25700 nM
Estimate against measurement, compound 4: 2.1-fold (0.32 log units) below; measured number above the stated range.
By their numbers in this assay, from the lowest: compounds 2, 3 and 1 (each within the scatter of the next); then compound 4.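

Putting 2,4-dichlorophenyl in place of 3-chlorophenyl on this nitrogen gives a 2.1-fold higher number from compound 3 to compound 4 (0.32 log units; beyond the scatter) in this assay, which means weaker inhibition. This is the first step among the compounds shown that goes beyond the scatter, so the chlorine pattern on this ring can shift the number, unlike the added chloro elsewhere in a 1.0-fold lower number from compound 1 to compound 2 (0.02 log units; within the scatter). Nothing available explains the shift. The compounds shown leave open whether the second chlorine or the missing chlorine at position 3 matters more, and how a methoxy group or an amine on this ring would read.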